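A few compounds are considered here, and "the series" means these few. Any claim that something is new, unique, unknown or untested is made for them only; others in the source may bear on it.

In a functional assay on HT-29 cells (Homo sapiens) for inhibition, read by MTT assay, with a stated time of 48 h (a higher number here means a weaker inhibitor, a lower number a stronger inhibitor), three compounds that share one core have been measured so far. Compound 1 `COc1cc(-c2nnc(S)n2-c2ccc(N(C)C)cc2)cc(OC)c1OC`, which carries a hydrogen on the sulfur, gives > 60000 nM, a limit of the assay and not a number. Compound 2 `COc1cc(-c2nnc(SCc3ccc(F)cc3)n2-c2ccc(N(C)C)cc2)cc(OC)c1OC` gives 44300 nM. Compound 3 `COc1cc(-c2nnc(SCC(=O)C3CC3)n2-c2ccc(N(C)C)cc2)cc(OC)c1OC` gives > 60000 nM, again only a limit, and this is where it stands.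

Compound 4 `CCOC(=O)CSc1nnc(-c2cc(OC)c(OC)c(OC)c2)n1-c1ccc(N(C)C)cc1` has ethoxy in place of cyclopropyl on a carbonyl carbon.

Going by the values given here, three measured steps concern the same side chain on the sulfur. Adding 4-fluorobenzyl gave an at least 1.3-fold lower number from compound 1 to compound 2 (0.13 log units; that floor lies within the scatter). Adding (cyclopropylcarbonyl)methyl gave a step that the two limits leave unreadable from compound 1 to compound 3. Exchanging one side chain for the other gave an at least 1.3-fold higher number from compound 2 to compound 3 (0.13 log units; that floor lies within the scatter). None of these steps has a readable size beyond the scatter, so no step beyond the scatter is expected in this assay, and no direction can be favoured. The estimated step is a number no higher from compound 3 to compound 4 (the limit leaves the size open). Compound 4 is expected at about 60000 nM, with an estimated range of 30000 nM to 120000 nM.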

Compound 4, half-maximal inhibitory concentration: 28800 nM
Beside the measured number, compound 4's estimate is 2.1-fold (0.32 log units) above it; measured number below the stated range.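

On the carbonyl carbon of the side chain on the sulfur, ethoxy in place of cyclopropyl gives an at least 2.0-fold lower number from compound 3 to compound 4 (0.31 log units; beyond the scatter), a size that no readable step among the other compounds showed. The whole (ethoxycarbonyl)methyl chain in place of hydrogen on the sulfur gives an at least 2.0-fold lower number from compound 1 to compound 4 (0.31 log units; beyond the scatter), while the exchange of 4-fluorophenyl for ethoxycarbonyl gives a 1.5-fold lower number from compound 2 to compound 4 (0.19 log units; within the scatter), so these two compounds cannot be told apart in this assay. The two steps beyond the scatter can be given only as floors because each starts from a limit, not a number: the limit of > 60000 nM in this assay, at which 2 of the 4 values shown sit.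

This change removes a ring and brings in an oxygen at once, and the compounds shown do not separate those two differences. A propyl group on the same carbonyl carbon would address that question, while an amide or a carboxylic acid there remains an open comparison.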